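Aryl swap on the ring nitrogen of compound 2

The source may report more compounds than this note shows. Statements on the series, on what has been measured and on what is new or still open speak of the compounds shown alone.

Measured compounds:
compound 1, `Cc1ccc(-n2nncc2CN2C(=O)C3(C(C#N)=C(N)Oc4c3c3nc5ccccc5nc3c3ccccc43)c3ccccc32)c(C)c1`, gives > 50000 nM in a functional assay on HCT-116 cells (Homo sapiens) for antiproliferative activity, read by MTT assay, with a stated time of 48 h; on this read-out higher numbers stand for weaker inhibition and lower numbers for stronger inhibition
compound 2, `N#CC1=C(N)Oc2c(N)cc3nc4ccccc4nc3c2C12C(=O)N(Cc1cnnn1-c1cccc(Br)c1)c1ccccc12`, gives 26100 nM in this assay

Of the compounds shown here, two have been measured. For compound 1 the result is a limit of this assay, not a number (the limit of > 50000 nM in this assay, at which 1 of the 2 values shown sits). Compound 2 is the only compound with a numerical value, so it stands alone among the numbers shown; compound 1 differs from it in more than one place, and no single step between the two is counted.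

Compound 3, `Cc1ccc(-n2nncc2CN2C(=O)C3(C(C#N)=C(N)Oc4c(N)cc5nc6ccccc6nc5c43)c3ccccc32)cc1C`, has not yet been measured. It differs from compound 2 in one place (3,4-dimethylphenyl in place of 3-bromophenyl on an aromatic nitrogen). The shared core of compound 2 and compound 3 is unchanged.

Among the measured compounds shown here, since no measured step separates two compounds that differ in one place, there is nothing to gauge the effect of this exchange against. The expectation for the step from compound 2 to compound 3 is therefore no change beyond the usual scatter of this assay a 1.1-fold higher number from compound 2 to compound 3 (0.06 log units; within the scatter). Compound 3 is thus expected to give about 30000 nM in this assay, within a range from 12000 nM to 80000 nM.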

Compound 3, half-maximal inhibitory concentration: > 50000 nM
Compound 3: no number, only a limit (the forecaster's own chance of this, stated with the estimate: 30%); middle value at least 1.6-fold (0.22 log units) from the limit.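

In this assay compound 3 gives > 50000 nM, which is a limit of the assay and not a number. Among the compounds shown here, this supplies the first step between two compounds that differ in one place: 3,4-dimethylphenyl in place of 3-bromophenyl on the aromatic nitrogen gives an at least 1.9-fold higher number from compound 2 to compound 3 (0.28 log units; that floor lies within the scatter), so this exchange does not bring the number down, although the floor of the step alone does not establish a real loss. The limit also restricts what can be read at this position, as most of the values shown now sit there: the limit of > 50000 nM in this assay, at which 2 of the 3 values shown sit.

As far as these compounds go, how far compound 3 lies beyond its limit remains open, so the true size of the step, and whether it exceeds the usual scatter, cannot be told. Also open, from the compounds shown here alone, is how the number would respond at this position to a plain phenyl, a 3-chlorophenyl or a 3-aminophenyl group, and whether any such exchange would move it clearly away from the value of compound 2, 26100 nM.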